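Swapping nitro for dimethylamino on the aryl arm

A few compounds are considered here, and "the series" means these few. Any claim that something is new, unique, unknown or untested is made for them only; others in the source may bear on it.

Three compounds share one core and differ in the aryl group attached to it and in the chains on the core. Compound 1, `CCCn1c(=O)c2nc(-c3ccc(S(=O)(=O)NCCCC(=O)OCC)cc3)[nH]c2n(CCC)c1=O`, binds most tightly: in an assay for binding affinity to adenosine receptor A1 (Bos taurus) (a lower number here means a stronger inhibitor, a higher number a weaker inhibitor), compound 1 gives 0.24 nM. Compound 3, `C=CCn1c(=O)c2nc(-c3ccc(Cl)cc3N)[nH]c2n(CC=C)c1=O`, gives 0.8 nM in this assay. Compound 2, `Cn1c(=O)c2nc(-c3cccc([N+](=O)[O-])c3)[nH]c2n(C)c1=O`, stands at the weak end of the three, with 50 nM in this assay, well beyond the scatter from both of the others.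

Compound 4, `CN(C)c1cccc(-c2nc3c(=O)n(C)c(=O)n(C)c3[nH]2)c1`, is not yet measured. Compared with compound 2, the change is dimethylamino in place of nitro on an aromatic carbon. Among the measured compounds shown here, no measured pair shows this exact swap, so the size of the step is unknown. The group keeps the same size, and the attachment point does not move, so a modest step is expected rather than a large one, in either direction. Compound 4 is expected to land near compound 2, with an estimated value of 40 nM, plausibly between 8 nM and 200 nM. The expected step from compound 2 to compound 4 is a 1.3-fold lower number from compound 2 to compound 4 (0.10 log units; within the scatter), within or just beyond the scatter.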

Compound 4, half-maximal inhibitory concentration: 80 nM
Compound 4: the middle estimate sits 2.0-fold (0.30 log units) below what was measured; the measured number falls inside the stated range.
By their numbers in this assay, from the lowest: compound 1; then compound 3; then compounds 2 and 4 (each within the scatter of the next).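

In this assay dimethylamino in place of nitro on this aromatic carbon gives a 1.6-fold higher number from compound 2 to compound 4 (0.20 log units; within the scatter) and so leaves the two compounds indistinguishable in this measurement. Among the compounds shown here, this is the first direct look at this position: two groups with different atoms, one with a double bond outside the ring and one without, and with 2 and 1 hydrogen-bond acceptors, give matching numbers here. No measurement offered here explains this match.

As far as these compounds go, whether a primary amine, a carboxylic acid or a longer chain on the same aromatic carbon would also leave the number unchanged remains open. Also open, from the compounds shown here alone, is whether the same swap would be as quiet on a compound carrying different chains on the shared core, such as the propyl groups of compound 1.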